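Methoxymethyl on the Pyridyl Core: Half-Life Expectation

The source may hold more compounds than are shown below. What is called first, only, known or untested is meant among the compounds shown, and "the series" means these compounds.

Measured compounds:
compound 1, `CC1=C(C(=O)NCCCN2CCC(c3ccccc3C#N)CC2)[C@@H](c2ccc(F)c(F)c2)NC(=O)N1`, 2.7 h
compound 2, `COCC1=C(C(=O)NCCCN2CCC(c3ccccc3C#N)CC2)[C@@H](c2ccc(F)c(F)c2)NC(=O)N1`, 1.8 h
compound 3, `CC1=C(C(=O)NCCCN2CCC(c3ccccn3)CC2)[C@@H](c2ccc(F)c(F)c2)NC(=O)N1`, 0.7 h

All three were run in an ADME assay on the whole organism with Rattus norvegicus as the target; on this read-out higher numbers stand for a longer-lived compound and lower numbers for a shorter-lived compound. Compound 2 differs from compound 1 by methoxy in place of hydrogen on a saturated chain carbon bound to a double-bonded ring carbon, and this gave a 1.5-fold lower number from compound 1 to compound 2 (0.18 log units; within the scatter). Compound 3 differs from compound 1 by pyridin-2-yl in place of 2-cyanophenyl on a saturated ring carbon, which gave a 3.9-fold lower number from compound 1 to compound 3 (0.59 log units; beyond the scatter); compound 3 thus stands lowest of the three. Compound 4, `COCC1=C(C(=O)NCCCN2CCC(c3ccccn3)CC2)[C@@H](c2ccc(F)c(F)c2)NC(=O)N1`, has not yet been measured in this assay. It differs from compound 3 by methoxy in place of hydrogen on a saturated chain carbon bound to a double-bonded ring carbon, the same change, in the same place, as that made from compound 1 to compound 2. For compound 4 a step of about a 1.4-fold lower number from compound 3 to compound 4 (0.15 log units; within the scatter) is expected, resting on the earlier step of a 1.5-fold lower number from compound 1 to compound 2 (0.18 log units; within the scatter), which stayed within the scatter. Compound 4 is therefore estimated at 0.5 h, between 0.25 h and 1 h.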

Compound 4, half-life: 7 h
The estimate for compound 4 lay 14-fold (1.15 log units) below the measured number; measured number outside the range, above it.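

In this assay, methoxy in place of hydrogen on a saturated chain carbon bound to a double-bonded ring carbon gave a 10-fold higher number from compound 3 to compound 4 (1.00 log units; beyond the scatter), and this did not repeat what the same change had done on the core of compound 1: the same change on two cores in this assay, a 1.5-fold lower number (0.18 log units; within the scatter) from compound 1 to compound 2 and a 10-fold higher number (1.00 log units; beyond the scatter) from compound 3 to compound 4, 15-fold (1.18 log units) apart, beyond the scatter of two such steps. Pyridin-2-yl in place of 2-cyanophenyl on a saturated ring carbon gave a 3.9-fold higher number from compound 2 to compound 4 (0.59 log units; beyond the scatter), which also differs from the step made with the methyl group in place: the same change on two cores in this assay, a 3.9-fold lower number (0.59 log units; beyond the scatter) from compound 1 to compound 3 and a 3.9-fold higher number (0.59 log units; beyond the scatter) from compound 2 to compound 4, 15-fold (1.18 log units) apart, beyond the scatter of two such steps. The effect of the change on half-life therefore did not carry from one core to the other here, but these four compounds do not show why, nor how it would behave on any further core.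

The compounds shown leave open whether an ethoxymethyl or a hydroxymethyl group in the same place would follow methoxymethyl on the core of compound 3. They also leave open which of the two cores a pyridin-3-yl group would resemble.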